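Swapping the amide substituent of compound 3 for a cyclohexyl

A few compounds are considered here, and "the series" means these few. Any claim that something is new, unique, unknown or untested is made for them only; others in the source may bear on it.

In a functional assay on Ramos cells (Homo sapiens) for antiproliferative activity, read by CCK-8 assay, with a stated time of 72 h, tested at 40 uM (on this read-out lower numbers stand for less inhibition and higher numbers for more inhibition at the one concentration tested (going by the name of the read-out)), compound 1 `CCOC(=O)c1sc(-c2cccc(NC(=O)c3ccccc3F)c2)nc1Nc1ccc(N2CCN(C)CC2)cc1` gives 96.4% and compound 2 `CCOC(=O)c1sc(-c2cccc(NC(=O)c3ccc(C#N)cc3)c2)nc1Nc1ccc(N2CCN(C)CC2)cc1` gives 97.5%; the step of a number 1.1 percentage points higher from compound 1 to compound 2 (within the scatter) lies within the scatter. Compound 3 `CCOC(=O)c1sc(-c2cccc(NC(=O)c3ccc(C(F)(F)F)cn3)c2)nc1Nc1ccc(N2CCN(C)CC2)cc1` gives 19%, the lowest of the three numbers, reached through the large drops a number 77.4 percentage points lower from compound 1 to compound 3 (beyond the scatter) and a number 78.5 percentage points lower from compound 2 to compound 3 (beyond the scatter). Compound 4 `CCOC(=O)c1sc(-c2cccc(NC(=O)[C@H]3CC[C@H](C)CC3)c2)nc1Nc1ccc(N2CCN(C)CC2)cc1` differs from compound 3 in one place: 4-methylcyclohexyl in place of 5-(trifluoromethyl)pyridin-2-yl on a carbonyl carbon. Both measured steps onto compound 3 act at the same carbonyl carbon, yet neither tests a non-aromatic ring there, so the direction is open: compound 1 and compound 2 gave high inhibition, compound 3 a low one. Compound 4 is expected to recover part of that inhibition, a number 41 percentage points higher from compound 3 to compound 4 (beyond the scatter), with an estimate of 60% (range 15% to 98%).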

Compound 4, a percentage reported as inhibition, at one concentration (the size of the read-out at that concentration, not a potency): 19.9%
The estimate for compound 4 lay 40.1 percentage points above the measured number; the range from low to high includes it.
By their numbers in this assay, from the lowest: compounds 3 and 4 (each within the scatter of the next); then compounds 1 and 2 (each within the scatter of the next).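

In this assay a non-aromatic ring on this carbonyl carbon does not bring the inhibition back: a number 0.9 percentage points higher from compound 3 to compound 4 (within the scatter) and so 4-methylcyclohexyl and 5-(trifluoromethyl)pyridin-2-yl cannot be told apart here. Against the substituted phenyl amides the drop is large in both cases, with a number 77.6 percentage points lower from compound 2 to compound 4 (beyond the scatter) and a number 76.5 percentage points lower from compound 1 to compound 4 (beyond the scatter) so among these four compounds high inhibition appears only with the 2-fluorophenyl and 4-cyanophenyl groups. Nothing available explains this result. Still open, on these data alone, is whether an unsubstituted phenyl ring keeps the high inhibition, and whether a pyridine ring without the trifluoromethyl group does. A piperidine ring bearing a free amine or a longer alkyl chain on the carbonyl carbon is equally untested by these compounds.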